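The source may hold more compounds than are shown below. What is called first, only, known or untested is meant among the compounds shown, and "the series" means these compounds.

Compound 1 `O=C(NCC1(c2nc(-c3ccccc3)cs2)CCOCC1)c1ccc(-c2cnco2)cc1` shares its core with compound 2 `O=C(NCC1(c2nc(-c3ccccc3)cs2)CCOCC1)c1ccc(-n2cncn2)cc1` and compound 3 `Cc1cnc(Nc2ccc(C(=O)NCC3(c4nc(-c5ccccc5)cs4)CCOCC3)cc2)s1`. In a physicochemical assay for solubility, read by chemiluminescence, in phosphate buffer, measured as kinetic solubility, at pH 7.4 (a lower number here means a less soluble compound, a higher number a more soluble compound), compound 1 gives 71000 nM, which is the lowest of the two numbers shown, and compound 2 gives 191000 nM. For compound 3 only the limit of < 1000 nM is known. The step of a 2.7-fold higher number from compound 1 to compound 2 (0.43 log units; beyond the scatter) is modest, while the steps of an at least 71-fold lower number from compound 1 to compound 3 (1.85 log units; beyond the scatter) and an at least 190-fold lower number from compound 2 to compound 3 (2.28 log units; beyond the scatter) are large, with compound 3 sitting at the limit of < 1000 nM in this assay, at which 1 of the 3 values shown sits.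

Compound 4 `O=C(NCC1(c2nc(-c3ccccc3)cs2)CCOCC1)c1ccc(Nc2nncs2)cc1` differs from compound 1 in one place: (1,3,4-thiadiazol-2-yl)amino in place of 1,3-oxazol-5-yl on an aromatic carbon. The step from compound 1 to compound 3 bears most closely on this, since both replace the 1,3-oxazol-5-yl with an amino-linked five-membered ring. The step of an at least 71-fold lower number from compound 1 to compound 3 (1.85 log units; beyond the scatter) was large and downward, so a similar large downward step is expected here, most likely taking compound 4 to the limit. The expected step for compound 4 is a 47-fold lower number from compound 1 to compound 4 (1.68 log units; beyond the scatter). Compound 4 is therefore estimated at 1500 nM, within the range 400 nM to 6000 nM.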

Compound 4, solubility: 29000 nM
The estimate for compound 4 lay 19-fold (1.29 log units) below the measured number; measured number outside the range, above it.
By their numbers in this assay, from the lowest: compound 4; then compound 1; then compound 2. At a limit, below all of these: compound 3.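

In this assay, an amino-linked five-membered ring on this aromatic carbon, para to a large group, does not by itself bring a large drop: a 2.4-fold lower number from compound 1 to compound 4 (0.39 log units; beyond the scatter) and a 6.6-fold lower number from compound 2 to compound 4 (0.82 log units; beyond the scatter) are both modest. The large difference lies instead in the ring carried on the nitrogen, where 1,3,4-thiadiazol-2-yl in place of 5-methyl-1,3-thiazol-2-yl gives an at least 29-fold higher number from compound 3 to compound 4 (1.46 log units; beyond the scatter). Compound 3 stands at a limit, so that step is a bound and not an exact size: the limit of < 1000 nM in this assay, at which 1 of the 4 values shown sits.

The compounds shown leave open whether that step follows the methyl or the ring nitrogen, which a 1,3-thiazol-2-yl or a 5-methyl-1,3,4-thiadiazol-2-yl on the same nitrogen would separate. Also open, on these data alone, is how a simple amine or a carboxylic acid would compare at this position.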